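The source may hold more compounds than are shown below. What is called first, only, known or untested is meant among the compounds shown, and "the series" means these compounds.

Measured compounds in a functional assay on MDA-MB-231 cells (Homo sapiens) for cytotoxicity, read by MTT assay, with a stated time of 96 h; on this read-out lower numbers stand for stronger inhibition and higher numbers for weaker inhibition:
- compound 1 `CC[C@H](N)C(=O)N[C@@H]1C(=O)N2[C@@H](CC[C@@H]1CCNC(=O)c1ccccc1)CC[C@H]2C(=O)NC(c1ccccc1)c1ccccc1` gives 930 nM
- compound 2 `CC[C@H](NC)C(=O)N[C@@H]1C(=O)N2[C@@H](CC[C@@H]1CCNC(=O)c1ccccc1)CC[C@H]2C(=O)NC(c1ccccc1)c1ccccc1` gives 210 nM
- compound 3 `CC[C@H](N)C(=O)N[C@@H]1C(=O)N2[C@@H](CC[C@@H]1CCNC(=O)NCc1ccccc1)CC[C@H]2C(=O)NC(c1ccccc1)c1ccccc1` gives 10800 nM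

Compound 2 is derived from compound 1 by the change (methyl in place of hydrogen on an amine nitrogen). This step reads a 4.4-fold lower number from compound 1 to compound 2 (0.65 log units; beyond the scatter), a gain that lies beyond the usual scatter. Compound 3 differs from compound 1 in its core, the change being (benzylamino in place of phenyl on a carbonyl carbon); the step reads a 12-fold higher number from compound 1 to compound 3 (1.06 log units; beyond the scatter), so compound 3 is the weakest of the three measured compounds, its distance to compound 2 also lying beyond the scatter.

Compound 4 `CC[C@H](NC)C(=O)N[C@@H]1C(=O)N2[C@@H](CC[C@@H]1CCNC(=O)NCc1ccccc1)CC[C@H]2C(=O)NC(c1ccccc1)c1ccccc1` has not been measured. Relative to compound 3 it carries the change (methyl in place of hydrogen on an amine nitrogen). Among the compounds with values here, this is the same change as the one from compound 1 to compound 2, on the same kind of amine nitrogen with the same neighbour, and it occurs twice in the set. The only difference between the two pairs is the core, as described by benzylamino in place of phenyl on a carbonyl carbon.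

With a single measured precedent, the expectation for compound 4 rests on the gain seen in a 4.4-fold lower number from compound 1 to compound 2 (0.65 log units; beyond the scatter) being carried over onto the core of compound 3. The step from compound 3 to compound 4 in this assay is therefore expected to be about a 3.9-fold lower number from compound 3 to compound 4 (0.59 log units; beyond the scatter), with somewhat wider uncertainty because the core change a 12-fold higher number from compound 1 to compound 3 (1.06 log units; beyond the scatter) is large and its interplay with the methyl cannot be read from one pair. Compound 4 is estimated at 2800 nM, within a range from 1000 nM to 8000 nM.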

Compound 4, half-maximal inhibitory concentration: 1200 nM
Compound 4: middle estimate off by 2.3-fold (0.37 log units), on the high side, and the stated range covers the measured number.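

In this assay, methyl in place of hydrogen on the amine nitrogen also lowers the number on the core of compound 3, with a 9.0-fold lower number from compound 3 to compound 4 (0.95 log units; beyond the scatter), and the step matches the one on the core of compound 1: the same change on two cores in this assay, a 4.4-fold lower number (0.65 log units; beyond the scatter) from compound 1 to compound 2 and a 9.0-fold lower number (0.95 log units; beyond the scatter) from compound 3 to compound 4, 2.0-fold (0.31 log units) apart, within the scatter of two such steps Read the other way, benzylamino in place of phenyl on a carbonyl carbon raises the number with the methyl present as well, with a 5.7-fold higher number from compound 2 to compound 4 (0.76 log units; beyond the scatter), and this step also matches its counterpart: the same change on two cores in this assay, a 12-fold higher number (1.06 log units; beyond the scatter) from compound 1 to compound 3 and a 5.7-fold higher number (0.76 log units; beyond the scatter) from compound 2 to compound 4, 2.0-fold (0.31 log units) apart, within the scatter of two such steps The two changes therefore carry over from one core to the other within the scatter in these four compounds, but this is a single set of pairs in one cell assay, so it does not show that the methyl step would hold on other cores or that the two step sizes are truly identical.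

From the compounds shown here alone, it remains open whether the step persists with ethyl in place of methyl on the amine nitrogen, or with a second methyl on that nitrogen. Going by these compounds, it is equally open how the methyl step behaves when the benzylamino group on the carbonyl carbon gives way to a longer chain such as phenethylamino, or to a plain methylamino group.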